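Removing a Fluoro Group Twice on One Shared Core

The source may report more compounds than this note shows. Statements on the series, on what has been measured and on what is new or still open speak of the compounds shown alone.

All values come from a functional assay on HCT-116 cells (Homo sapiens) for antiproliferative activity, read by MTT assay, with a stated time of 48 h; a higher number here means a weaker inhibitor, a lower number a stronger inhibitor.
Compound 1 `CCCCC(CCO)n1cnc2c(Cl)nc(F)nc21` gives 13500 nM.
Compound 2 `CCCCC(CCO)n1cnc2c(Cl)ncnc21` reaches only a limit of this assay, > 50000 nM.
Compound 3 `CCCCCCC(CCO)n1cnc2c(Cl)nc(F)nc21` gives 9960 nM.

From compound 1 to compound 2 the change is hydrogen in place of fluoro on an aromatic carbon; it produced an at least 3.7-fold higher number from compound 1 to compound 2 (0.56 log units; beyond the scatter), with compound 2 sitting at the limit of > 50000 nM in this assay, at which 1 of the 3 values shown sits. The cores of compound 1 and compound 3 differ by ethyl in place of hydrogen on a saturated chain carbon, five bonds along the chain from an aromatic nitrogen, a change that gave a 1.4-fold lower number from compound 1 to compound 3 (0.13 log units; within the scatter). Compound 4 `CCCCCCC(CCO)n1cnc2c(Cl)ncnc21` is not yet measured; it differs from compound 3 by hydrogen in place of fluoro on an aromatic carbon, the same change at a place described in the same words. Because the earlier removal gave an at least 3.7-fold higher number from compound 1 to compound 2 (0.56 log units; beyond the scatter), a step of about a 5.0-fold higher number from compound 3 to compound 4 (0.70 log units; beyond the scatter) is expected here as well. Compound 4 is therefore estimated at 50000 nM, quite possibly reported only as a limit again, within 25000 nM to 150000 nM.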

Compound 4, half-maximal inhibitory concentration: 11900 nM
The estimate for compound 4 lay 4.2-fold (0.62 log units) above the measured number; measured number below the stated range.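

In this assay, replacing fluoro with hydrogen did not carry over cleanly from one core to the other: on the core of compound 3 it gave a 1.2-fold higher number from compound 3 to compound 4 (0.08 log units; within the scatter), and the two steps differ: the same change on two cores in this assay, an at least 3.7-fold higher number (0.56 log units; beyond the scatter) from compound 1 to compound 2 and a 1.2-fold higher number (0.08 log units; within the scatter) from compound 3 to compound 4, at least 3.0-fold (0.49 log units) apart, beyond the scatter of two such steps. Adding the ethyl also depended on the core, giving an at least 4.2-fold lower number from compound 2 to compound 4 (0.62 log units; beyond the scatter) when hydrogen rather than fluoro sat on the aromatic carbon, which again differs from the earlier step: the same change on two cores in this assay, a 1.4-fold lower number (0.13 log units; within the scatter) from compound 1 to compound 3 and an at least 4.2-fold lower number (0.62 log units; beyond the scatter) from compound 2 to compound 4, at least 3.0-fold (0.49 log units) apart, beyond the scatter of two such steps. The reading for compound 2, > 50000 nM, is only a limit; the true size of the steps involving it remains unknown, and these compounds do not show why the steps differ.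

From the compounds shown here alone, it remains open how an amine in place of the fluoro group would behave on either core. Going by these compounds, it is equally open whether a longer chain would follow the pattern of compound 3 and compound 4.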